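A few compounds are considered here, and "the series" means these few. Any claim that something is new, unique, unknown or untested is made for them only; others in the source may bear on it.

Working notes on the bis(trifluoromethyl)benzenesulfonamide series.

Of the compounds shown here, three have been measured in a functional assay on HPAC cells (Homo sapiens) for inhibition, read by MTT assay, with a stated time of 72 h; a higher number here means a weaker inhibitor of growth, a lower number a stronger inhibitor of growth. Compound 1 `O=S(=O)(NCCCNCc1ccc(-c2ccccc2)cc1)c1cc(C(F)(F)F)cc(C(F)(F)F)c1` gives 2700 nM. Compound 2 `O=S(=O)(NCCCNCc1ccc(Cl)c(C(F)(F)F)c1)c1cc(C(F)(F)F)cc(C(F)(F)F)c1` gives 3000 nM. Compound 3 `CN(CCCNS(=O)(=O)c1cc(C(F)(F)F)cc(C(F)(F)F)c1)Cc1ccccc1` gives 30000 nM, the highest of the three numbers: its distance from compound 2 and from compound 1 lies beyond the scatter in each case, so compound 3 is the weakest growth inhibitor among the measured set.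

Compound 4 `COc1ccc(CNCCCNS(=O)(=O)c2cc(C(F)(F)F)cc(C(F)(F)F)c2)cc1` has not yet been measured in this assay. Relative to compound 3 the change is (4-methoxybenzyl)amino in place of benzyl(methyl)amino on a saturated chain carbon, three bonds along the chain from a sulfonamide nitrogen. Compound 4 thereby shares with compound 1 and compound 2 a chain nitrogen that carries no methyl, which compound 3 alone has, while its ring substituent is new to the series.

Since compound 1 at 2700 nM and compound 2 at 3000 nM both sit well under compound 3, the step from compound 3 to compound 4 is expected to lower the number and to exceed the scatter, estimated at a 7.5-fold lower number from compound 3 to compound 4 (0.88 log units; beyond the scatter). For compound 4 the expected value in this assay is 4000 nM, within a range of 1500 nM to 12000 nM.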

Compound 4, concentration for 50% growth inhibition: 3000 nM
Beside the measured number, compound 4's estimate is 1.3-fold (0.12 log units) above it; measured number inside the range.
By their numbers in this assay, from the lowest: compounds 1, 2 and 4 (each within the scatter of the next); then compound 3.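

In this assay, going by these compounds alone, (4-methoxybenzyl)amino in place of benzyl(methyl)amino on the saturated chain carbon gives a 10-fold lower number from compound 3 to compound 4 (1.00 log units; beyond the scatter), the first step to connect compound 3 with a compound on the lower-number side. Within the data shown here, the two further steps show that the new ring substituent leaves compound 4 level with the earlier compounds that have no methyl on the chain nitrogen: 4-methoxyphenyl in place of 4-chloro-3-(trifluoromethyl)phenyl gives no change at the digits printed from compound 2 to compound 4 (within the scatter), and methoxy in place of phenyl on an aromatic carbon gives a 1.1-fold higher number from compound 1 to compound 4 (0.05 log units; within the scatter), so compounds 1, 2 and 4 show no order among them. No accompanying measurement speaks to the reason for any of these steps.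

The step from compound 3 carries two changes inside one group, loss of the methyl and gain of the methoxy, so the share of each remains unreadable; unsubstituted benzylamino, or (4-methoxybenzyl)(methyl)amino, would separate them. Also open, going by these compounds, is whether this level holds with a carboxylic acid on the ring or with a longer chain between the two nitrogens.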